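The compounds below may be only part of what the source reports. "The series", "measured", "known", "first", "only" and "open" are said of these compounds alone.

Among the measured compounds shown here, compound 2 `O=C(/C=C\c1ccccc1O)N1N=C(c2ccncc2)OC1c1c[nH]c2ccccc12` is the one member of the series with a number in an ADME assay on HeLa cells (Homo sapiens) for cytotoxicity, read by MTT assay, with a stated time of 72 h; on this read-out higher numbers stand for weaker inhibition of growth and lower numbers for stronger inhibition of growth: compound 2 gives 26.8 ug/mL. Compound 1 `O=C(/C=C\c1ccccc1)N1N=C(c2ccncc2)OC1c1c[nH]c2ccccc12` reaches only the limit of the assay in this assay, reported as > 30 ug/mL. Compound 3 `O=C(/C=C\c1ccc(O)cc1)N1N=C(c2ccncc2)OC1c1c[nH]c2ccccc12` likewise sits at that limit in this assay, given as > 30 ug/mL. Compound 4 `O=C(/C=C\c1ccccc1Cl)N1N=C(c2ccncc2)OC1c1c[nH]c2ccccc12` differs from compound 2 by chloro in place of hydroxy on an aromatic carbon. For the measured compounds named here, the steps that bear on this change are an at least 1.1-fold lower number from compound 1 to compound 2 (0.04 log units; that floor lies within the scatter) and an at least 1.1-fold higher number from compound 2 to compound 3 (0.04 log units; that floor lies within the scatter), both within the scatter, while a step that the two limits leave unreadable from compound 1 to compound 3 cannot be read. No step beyond the scatter is therefore expected in this assay, and the limit of > 30 ug/mL in this assay, at which 2 of the 3 values shown sit, may well be reached again. Compound 4 is estimated at 30 ug/mL, range 15 ug/mL to 60 ug/mL, meaning an expected step of a 1.1-fold higher number from compound 2 to compound 4 (0.05 log units; within the scatter).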

Compound 4, concentration for 50% growth inhibition: > 30 ug/mL
Compound 4 gave a limit, no number; the forecaster's own chance of this, stated with the estimate: 55%; the middle value lies on the limit itself.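

In this assay, chloro in place of hydroxy on this aromatic carbon, ortho to a large group, gives an at least 1.1-fold higher number from compound 2 to compound 4 (0.04 log units; that floor lies within the scatter). The steps to compound 4 from compound 1 and from compound 3 join two limits and cannot be read. With compound 4 added, the series gathers further at one limit: the limit of > 30 ug/mL in this assay, at which 3 of the 4 values shown sit.

The compounds shown leave open whether an amine or a methoxy group on this aromatic carbon would give a step beyond the scatter. They also leave open how the hydroxy and chloro groups compare on a scale free of this limit.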